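The compounds below may be only part of what the source reports. "The series", "measured", "known", "first", "only" and "open" are said of these compounds alone.

Compound 1 `C/C(=C\CC/C(C)=C/CC[C@@H]1[C@@]2(C)CCC(=O)C(C)(C)[C@H]2CC[C@@]1(C)O)CC/C=C(\C)C(=O)OCc1cn(-c2ccc(F)cc2)nn1`, compound 2 `C/C(=C\CC/C(C)=C/CC[C@@H]1[C@@]2(C)CCC(=O)C(C)(C)[C@H]2CC[C@@]1(C)O)CC/C=C(\C)C(=O)OCc1cn(-c2ccc(F)c(Cl)c2)nn1` and compound 3 `C/C(=C\CC/C(C)=C/CC[C@@H]1[C@@]2(C)CCC(=O)C(C)(C)[C@H]2CC[C@@]1(C)O)CC/C=C(\C)C(=O)OCc1cn(-c2cccc(Cl)c2)nn1` share one core and differ only in the aromatic ring on the triazole. In a functional assay on DU-145 cells (Homo sapiens) for antiproliferative activity, read by MTT assay, with a stated time of 48 h (a lower number here means a stronger inhibitor, a higher number a weaker inhibitor), compound 1 gives > 150000 nM, which is a limit of the assay and not a number. In this assay compound 2 gives > 150000 nM, likewise a limit. In this assay compound 3 gives 103000 nM. From compound 2 to compound 1 the change is hydrogen in place of chloro on an aromatic carbon, and its step is a step that the two limits leave unreadable from compound 2 to compound 1, since both values sit at the limit of > 150000 nM in this assay, at which 2 of the 3 values shown sit. Compound 3 differs from compound 2 by hydrogen in place of fluoro on an aromatic carbon, with an at least 1.4-fold lower number from compound 2 to compound 3 (0.16 log units; that floor lies within the scatter) and an at least 1.4-fold lower number from compound 1 to compound 3 (0.16 log units; that floor lies within the scatter). Compound 4 `C/C(=C\CC/C(C)=C/CC[C@@H]1[C@@]2(C)CCC(=O)C(C)(C)[C@H]2CC[C@@]1(C)O)CC/C=C(\C)C(=O)OCc1cn(-c2ccccc2)nn1` is not yet measured and differs from compound 3 by hydrogen in place of chloro on an aromatic carbon, the same kind of change as from compound 2 to compound 1, except that there the place was ortho to a fluoro group. Compound 4 is expected to give 150000 nM, between 60000 nM and 400000 nM. That expected step of a 1.5-fold higher number from compound 3 to compound 4 (0.16 log units; within the scatter) rests on compound 3 at 103000 nM and on the earlier step that the two limits leave unreadable from compound 2 to compound 1 offering no readable size.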

Compound 4, half-maximal inhibitory concentration: 95500 nM
Estimate against measurement, compound 4: 1.6-fold (0.20 log units) above, and the stated range covers the measured number.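

In this assay, hydrogen in place of chloro brings a 1.1-fold lower number from compound 3 to compound 4 (0.03 log units; within the scatter), and phenyl in place of 3-chloro-4-fluorophenyl brings an at least 1.5-fold lower number from compound 2 to compound 4 (0.19 log units; that floor lies within the scatter). Hydrogen in place of fluoro brings an at least 1.5-fold lower number from compound 1 to compound 4 (0.19 log units; that floor lies within the scatter), and how far this change carries from one core to another can be judged only this far: the same change on two cores in this assay, an at least 1.4-fold lower number (0.16 log units; that floor lies within the scatter) from compound 2 to compound 3 and an at least 1.5-fold lower number (0.19 log units; that floor lies within the scatter) from compound 1 to compound 4; the limit leaves it open whether they differ Compound 1 and compound 2 each stand at a limit of the assay and not at a number, so neither step shows a true size, and the data do not show that the change has the same effect on both cores: the limit of > 150000 nM in this assay, at which 2 of the 4 values shown sit.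

The compounds shown leave open whether an amine or a carboxylic acid on the phenyl ring would give a clearly lower number. They also leave open whether a longer chain between the triazole and the phenyl ring would do so.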